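The compounds below may be only part of what the source reports. "The series", "measured", "known", "first", "only" and "open" are said of these compounds alone.

Measured compounds:
- compound 1, `O=C(Nc1nn[nH]n1)c1cccc(Br)n1`, gives 48% in a functional assay on the whole organism for inhibition, with Rattus norvegicus as the target, at a dose of 10 mg/kg by the oral route; on this read-out higher numbers stand for a stronger effect at the one dose given and lower numbers for a weaker effect
- compound 2, `O=C(Nc1nn[nH]n1)c1cccc(Oc2ccccc2)n1`, gives 0% in this assay
- compound 3, `O=C(Nc1nn[nH]n1)c1ccccn1`, gives 35% in this assay

Compound 3 stands second highest of the three numbers. Its nearest neighbour is compound 1, the step being a number 13 percentage points lower from compound 1 to compound 3 (beyond the scatter); the furthest is compound 2, where the step of a number 35 percentage points higher from compound 2 to compound 3 (beyond the scatter) separates them. Both steps lie beyond the scatter.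

Compound 4, `O=C(Nc1nn[nH]n1)c1cccc(Cl)n1`, is not yet measured in this assay. Its difference from compound 3 is chloro in place of hydrogen on an aromatic carbon.

Within the data shown here, the measured step that bears most directly on this is the one from compound 1 to compound 3, where hydrogen replaced bromo at the same carbon: a number 13 percentage points lower from compound 1 to compound 3 (beyond the scatter), a modest loss. Compound 4 runs that change in the reverse sense with a different halogen, so a modest gain is expected. The step from compound 2 to compound 3, a number 35 percentage points higher from compound 2 to compound 3 (beyond the scatter), concerns phenoxy and does not bear on a halogen directly. Among the measured compounds shown here, no chloro analogue has been measured, so the size of the step rests on a single bromo comparison.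

For compound 4 the expected change from compound 3 is a number 10 percentage points higher from compound 3 to compound 4 (within the scatter), and the estimated value is 45%, within a range from 30% to 60%.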

Compound 4, a percentage reported as inhibition, in the whole organism at one dose (the size of the read-out at that dose, not a potency): 13%
Estimate against measurement, compound 4: 32 percentage points above; the whole stated range lies above it.
By their numbers in this assay, from the lowest: compound 2; then compound 4; then compound 3; then compound 1.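

In this assay, the carbon next to the ring nitrogen does not respond to a halogen in a single direction: chloro in place of hydrogen gives a loss (a number 22 percentage points lower from compound 3 to compound 4 (beyond the scatter)), whereas the earlier bromo comparison points the opposite way (a number 13 percentage points lower from compound 1 to compound 3 (beyond the scatter)). The identity of the halogen therefore matters in its own right, as the direct exchange of bromo for chloro shows a large step (a number 35 percentage points lower from compound 1 to compound 4 (beyond the scatter)), while chloro still stands clear of phenoxy (a number 13 percentage points higher from compound 2 to compound 4 (beyond the scatter)), so that hydrogen, not chloro, is the closest of the three to bromo. Nothing available alongside these numbers accounts for the gap between the two halogens.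

With only bromo, chloro, hydrogen and phenoxy at this carbon, the compounds shown do not tell how fluoro, methyl, an amine or a carboxylic acid would read out there, or whether bromo is an isolated case among the groups at this position. They also leave open whether this order would hold at another dose, since each number comes from one dose only.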